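This account rests on a few compounds, and the source may have more. Where it says the series, first, only, none or still open, it means among the compounds named here.

Going by the values given here, compound 3 `CNC(=O)c1cc(Oc2ccc(C(=O)/C=C/c3cccc(Br)c3)cc2)ccn1` is the one member of this small set with a number: compound 3 gives 9940 nM in a functional assay on A549 cells (Homo sapiens) for cytotoxicity, read by MTT assay, with a stated time of 72 h; a lower number here means a stronger inhibitor, a higher number a weaker inhibitor. Its two companions were not measured in this assay: compound 1 `CNC(=O)c1cc(Oc2ccc(/C=C/C(=O)c3ccc(C)cc3)cc2)ccn1` has only the entry "not determined" (no result reported), and compound 2 `CNC(=O)c1cc(Oc2ccc(/C=C/C(=O)c3ccc(Cl)cc3)cc2)ccn1` likewise has only the entry "not determined" (no result reported), so no result exists for either, and compound 3 therefore stands alone on the numbers, with nothing to rank it against.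

Compound 4 `CNC(=O)c1cc(Oc2ccc(C(=O)/C=C/c3ccc(Cl)c(Cl)c3)cc2)ccn1` is the next compound to be tested in this assay. It differs from compound 3 in a single place: 3,4-dichlorophenyl in place of 3-bromophenyl on a double-bonded chain carbon bound to a double-bonded chain carbon. The rest of the molecule, the shared core with its carbonyl and double-bonded chain, is unchanged.

Among the compounds with values here, no step between measured compounds exists to guide the expectation, so the forecast for compound 4 rests on compound 3 alone. The exchange of one halogenated phenyl for another is expected to leave the potency roughly where compound 3 sits, giving an expected step from compound 3 to compound 4 of a 1.2-fold lower number from compound 3 to compound 4 (0.09 log units; within the scatter), that is, no change beyond the usual scatter. Compound 4 is accordingly estimated at 8000 nM in this assay, within a range from 3000 nM to 25000 nM.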

Compound 4, half-maximal inhibitory concentration: 33700 nM
Estimate against measurement, compound 4: 4.2-fold (0.62 log units) below; the whole stated range lies below it.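

In this assay, the group on a double-bonded chain carbon bound to a double-bonded chain carbon now proves able to shift the read-out: 3,4-dichlorophenyl in place of 3-bromophenyl gives a 3.4-fold higher number from compound 3 to compound 4 (0.53 log units; beyond the scatter) and so moves toward weaker inhibition. At this position, therefore, one halogen-bearing phenyl does not simply stand in for another, which compound 3 alone could not show. Nothing available here offers an explanation for this step.

Going by these compounds, the exchange of bromine for chlorine and the presence of a second halogen arrive together in this one step, and their separate contributions remain open. Also open, on these data alone, is how a plain phenyl, or a phenyl carrying a methoxy group or a dimethylamino group, would read at this place.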